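Aryl swap from compound 3 to compound 4

A few compounds are considered here, and "the series" means these few. Any claim that something is new, unique, unknown or untested is made for them only; others in the source may bear on it.

Measured compounds:
compound 1 `CS(=O)(=O)c1ccc(-c2oc3ccccc3c(=O)c2-c2ccc(F)cc2)cc1`: < 8%
compound 2 `COc1ccc(-c2c(-c3ccc(S(N)(=O)=O)cc3)oc3ccccc3c2=O)cc1`: 84%
compound 3 `CS(=O)(=O)c1ccc(-c2oc3ccccc3c(=O)c2-c2cc(Cl)cc(Cl)c2)cc1`: < 5%

In an assay on isolated protein for inhibition of prostaglandin G/H synthase 1 (Mus musculus), tested at 10 ug/mL (on this read-out lower numbers stand for less inhibition and higher numbers for more inhibition at the one concentration tested (going by the name of the read-out)), compound 3 gives < 5%, which is a limit of the assay and not a number. Compound 1 likewise sits at a limit, < 8%. Compound 2 gives 84%. Going by the values given here, the only single-place step, a step that the two limits leave unreadable from compound 1 to compound 3, cannot be read: both of its ends rest on limits, the limit of < 5% in this assay, at which 1 of the 3 values shown sits, and (the limit of < 8% in this assay, at which 1 of the 3 values shown sits). Compound 4 `COc1ccc(-c2c(-c3ccc(S(C)(=O)=O)cc3)oc3ccccc3c2=O)cc1` differs from compound 3 by 4-methoxyphenyl in place of 3,5-dichlorophenyl on an aromatic carbon. Among the compounds with values here, compound 2 carries the same 4-methoxyphenyl but differs from compound 4 in a second place as well, so its value shows only that this group can sit in a strongly inhibiting compound. Within the data shown here, no measured step bears directly on the change, and the step of a number at least 25 percentage points higher from compound 3 to compound 4 (beyond the scatter) is expected to be upward but of uncertain size. Compound 4 is estimated at 30%, in the range 5% to 80%.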

Compound 4, a percentage reported as inhibition, at one concentration (the size of the read-out at that concentration, not a potency): < 5%
Compound 4 ended at the assay's limit; the forecaster's own chance of this, stated with the estimate: 35%; at least 25 percentage points between middle value and limit.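

In this assay, with 4-methoxyphenyl held, methyl in place of amino on the sulfonyl sulfur gives a number at least 79 percentage points lower from compound 2 to compound 4 (beyond the scatter), so 4-methoxyphenyl alone does not carry the inhibition. Compound 4 gives < 5%, which is a limit of the assay and not a number. The steps into compound 4 from compound 1 and compound 3 cannot be read: the limit of < 5% in this assay, at which 2 of the 4 values shown sit.

Open, on these data alone, is whether amino on the sulfonyl sulfur also lifts inhibition with 4-fluorophenyl or 3,5-dichlorophenyl on the core. Also open, as far as these compounds go, is whether dimethylamino on that sulfur keeps any of it.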